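Side chain change on the amide: compound 2 to compound 3

A few compounds are considered here, and "the series" means these few. Any claim that something is new, unique, unknown or untested is made for them only; others in the source may bear on it.

Measured in a functional assay on MCF7 cells (Homo sapiens) for antiproliferative activity, read by MTT assay, with a stated time of 24 h; on this read-out lower numbers stand for stronger inhibition and higher numbers for weaker inhibition:
- compound 1 `CCn1c(C(=O)NCCN)ccc1C(CC)(CC)c1ccc(OCS(=O)(=O)c2ccccc2)c(C)c1`: 6470 nM
- compound 2 `CCn1c(C(=O)N[C@@H](CO)C(C)C)ccc1C(CC)(CC)c1ccc(OCS(=O)(=O)c2ccccc2)c(C)c1`: 18800 nM

Among the compounds with values here, compound 2 holds the higher of the two numbers, at 18800 nM, and its only neighbour is compound 1 at 6470 nM.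

The next structure is compound 3 `CCn1c(C(=O)NCCCO)ccc1C(CC)(CC)c1ccc(OCS(=O)(=O)c2ccccc2)c(C)c1`. The change is 3-hydroxypropyl in place of 1-(hydroxymethyl)-2-methylpropyl on an amide-type nitrogen, and the defined stereocentre of compound 2 goes with the leaving group.

Within the data shown here, one measured step bears on this place, and it involves compound 2 itself: a 2.9-fold higher number from compound 1 to compound 2 (0.46 log units; beyond the scatter), a modest step. It is the only measure of how far a change on this nitrogen moves the number, and the data do not show which feature of the side chain matters. A single step is thin support, so only a modest move toward lower numbers is expected in this assay, not one larger than that step.

In this assay the expected step is a 2.1-fold lower number from compound 2 to compound 3 (0.32 log units; beyond the scatter).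

For compound 3 the estimated value is 9000 nM, with an expected range of 4000 nM to 20000 nM.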

Compound 3, half-maximal inhibitory concentration: 42000 nM
The estimate for compound 3 lay 4.7-fold (0.67 log units) below the measured number; measured number outside the range, above it.
By their numbers in this assay, from the lowest: compound 1; then compound 2; then compound 3.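

In this assay, 3-hydroxypropyl (4 heavy atoms, no defined stereocentre) in place of 1-(hydroxymethyl)-2-methylpropyl (6 heavy atoms, 1 defined stereocentre) gives a 2.2-fold higher number from compound 2 to compound 3 (0.35 log units; beyond the scatter) and so moves the number up, which shows that dropping the stereocentre and the two heavy atoms does not bring the series back toward compound 1. Hydroxymethyl in place of amino on the saturated chain carbon gives a 6.5-fold higher number from compound 1 to compound 3 (0.81 log units; beyond the scatter) as the largest step on this nitrogen so far, and compound 1, the only one of the three with a terminal amino group, keeps the lowest number, with both of its steps beyond the scatter. No measurement shown here gives a reason for either step.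

The compounds shown do not separate the terminal amino group from the length of the chain, a question that a 3-aminopropyl group on the same nitrogen would address. Also open, on these data alone, are how a carboxylic acid or a dimethylamino group at the chain end would read, and whether the mirror-image form of the side chain of compound 2 would read differently from compound 2.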